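Swapping the Aryloxy Arm of Compound 3 for Fluorophenyl

A few compounds are considered here, and "the series" means these few. Any claim that something is new, unique, unknown or untested is made for them only; others in the source may bear on it.

Three compounds have numbers in an ADME assay on HepG2 cells (Homo sapiens) for cytotoxicity, read by luminescence, CellTiter-Glo and ATP content, with a stated time of 72 h; on this read-out higher numbers stand for an effect only at larger amounts of compound and lower numbers for an effect already at smaller amounts. Compound 1 `COc1ccc(Oc2ccc3c(NCCCNCc4cccc(OC)c4O)ccnc3c2)cc1` gives 5500 nM, compound 2 `COc1ccc(F)cc1CNCCCNc1ccnc2cc(-c3ccc(F)cc3)ccc12` gives 770 nM, and compound 3 `COc1cccc(CNCCCNc2ccnc3cc(Oc4cccc(N(C)C)c4)ccc23)c1O` gives 7300 nM, the highest of the three; its nearest neighbour is compound 1 and its furthest is compound 2. Within the data shown here, the only single-point step measured, a 1.3-fold higher number from compound 1 to compound 3 (0.12 log units; within the scatter), exchanged one aryloxy group for another. Compound 4 `COc1cccc(CNCCCNc2ccnc3cc(-c4ccc(F)cc4)ccc23)c1O` differs from compound 3 in this way: 4-fluorophenyl in place of 3-(dimethylamino)phenoxy on an aromatic carbon. Among the measured compounds shown here, no measured step covers this exact change, but compound 2, which also carries a 4-fluorophenyl on an aromatic carbon of its core, sits well below compound 3. A lower number for compound 4 is therefore expected, with a step of a 4.9-fold lower number from compound 3 to compound 4 (0.69 log units; beyond the scatter). Compound 4 is estimated at 1500 nM, within 500 nM to 4500 nM.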

Compound 4, half-maximal effective concentration: 6840 nM
Compound 4: middle estimate off by 4.6-fold (0.66 log units), on the low side; measured number outside the range, above it.
By their numbers in this assay, from the lowest: compound 2; then compounds 1, 4 and 3 (each within the scatter of the next).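

In this assay, the aromatic carbon of the core showed no response to losing the oxygen-linked aryl group, with 4-fluorophenyl reading the same as 3-(dimethylamino)phenoxy (a 1.1-fold lower number from compound 3 to compound 4 (0.03 log units; within the scatter)) and 4-methoxyphenoxy (a 1.2-fold higher number from compound 1 to compound 4 (0.09 log units; within the scatter)). The change on the saturated chain carbon, 2-hydroxy-3-methoxyphenyl in place of 5-fluoro-2-methoxyphenyl, instead gave a step beyond the scatter (an 8.9-fold higher number from compound 2 to compound 4 (0.95 log units; beyond the scatter)). Nothing available explains these steps. Going by these compounds, whether a morpholine or a carboxylic acid at the aromatic carbon would also leave the number unchanged remains open. So does whether 5-fluoro-2-methoxyphenyl gives the same step alongside an aryloxy group.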